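A nitrile gives way to an azidomethyl arm

The source may report more compounds than this note shows. Statements on the series, on what has been measured and on what is new or still open speak of the compounds shown alone.

Of the compounds shown here, two on a shared core have been measured. Compound 1 `Fc1cccc(F)c1Cn1c(-c2c(F)cccc2F)nc2c(Cl)cccc21` carries a chloro group on one aromatic carbon of its core; in a toxicity assay on CCRF-CEM cells (Homo sapiens) for cytotoxicity (a higher number here means that more compound is tolerated, a lower number that less compound is tolerated), compound 1 gives 30.4 uM. Compound 2 `N#Cc1cccc2c1nc(-c1c(F)cccc1F)n2Cc1c(F)cccc1F` bears a cyano at that place instead; in this assay compound 2 gives 26.7 uM. Going by the values given here, the only step between measured compounds is a 1.1-fold lower number from compound 1 to compound 2 (0.06 log units; within the scatter), which is within the scatter. Among the compounds with values here, compound 2 thus holds the lower of the two numbers, but its only neighbour, compound 1, lies within the scatter of it, so no order between them can be read.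

Compound 3 `[N-]=[N+]=NCc1cccc2c1nc(-c1c(F)cccc1F)n2Cc1c(F)cccc1F` differs from compound 2 in one place: azidomethyl in place of cyano on an aromatic carbon. Within the data shown here, no measured step touches the azidomethyl group, and the single step that exists at this position concerns a different exchange and stayed within the scatter. On that basis the change from compound 2 to compound 3 is expected to bring no shift beyond the scatter in this assay, an estimated 1.0-fold higher number from compound 2 to compound 3 (0.00 log units; within the scatter). Compound 3 is therefore estimated at 27 uM, with a range from 13 uM to 55 uM.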

Compound 3, half-maximal toxic concentration: > 100 uM
Compound 3: no number, only a limit; the forecaster's own chance of this, stated with the estimate: 5%; middle value at least 3.7-fold (0.56 log units) from the limit.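

The position on the aromatic carbon, which showed nothing beyond the scatter when chloro gave way to cyano, does respond in this assay once azidomethyl enters: the exchange for cyano gives an at least 3.7-fold higher number from compound 2 to compound 3 (0.57 log units; beyond the scatter), and the exchange for chloro gives an at least 3.2-fold higher number from compound 1 to compound 3 (0.51 log units; beyond the scatter). The group at this place can therefore change how much compound is tolerated, and both steps that reach azidomethyl run in the same direction, toward more compound being tolerated. The value of compound 3, > 100 uM, is a limit of the assay and not a number: the limit of > 100 uM in this assay, at which 1 of the 3 values shown sits.

The compounds shown leave open how large the two steps really are and which part of the azidomethyl group goes with the shift, the azide end or the added carbon. An aminomethyl or hydroxymethyl group at this place, or a longer chain ending in an azide, would bear on that question, and none of these stands among the compounds shown here.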